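Aryl urea series: ethoxycarbonyl in place of trifluoromethyl

A few compounds are considered here, and "the series" means these few. Any claim that something is new, unique, unknown or untested is made for them only; others in the source may bear on it.

Three compounds of the shared core have numbers in an ADME assay on the whole organism with Oryza sativa as the target, tested at 10 uM; a higher number here means a weaker effect of the compound at the concentration tested, a lower number a stronger effect. Compound 1 `CCCCc1ccc(NC(=O)N[C@@H](C)c2ccccc2)cc1` gives 60%. Compound 2 `CCCCCc1ccc(NC(=O)N[C@@H](C)c2ccccc2)cc1` gives 93%. Compound 3 `C[C@H](NC(=O)Nc1ccc(C(F)(F)F)cc1)c1ccccc1` gives 94%. Compound 3 stands highest of the three, but its nearest neighbour is close: a number 1 percentage points higher from compound 2 to compound 3 (within the scatter). The only wide gap is to compound 1: a number 34 percentage points higher from compound 1 to compound 3 (beyond the scatter). Within the pair of chain homologues, a number 33 percentage points higher from compound 1 to compound 2 (beyond the scatter).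

The next compound, compound 4 `CCOC(=O)c1ccc(NC(=O)N[C@@H](C)c2ccccc2)cc1`, differs from compound 3 in one place: ethoxycarbonyl in place of trifluoromethyl on an aromatic carbon.

Within the data shown here, no measured step exchanges the trifluoromethyl for anything other than a chain; the two steps that reach compound 3 both replace an alkyl chain, and they are of very different size depending on the chain left behind. Nothing here speaks to an ethoxycarbonyl. Two of three compounds sit near the top of the scale, and only compound 1 sits far lower, so the expectation is that compound 4 stays high, with a broad range below it. For compound 4 the expected step is a number 12 percentage points lower from compound 3 to compound 4 (beyond the scatter). Compound 4 is estimated at 82%, with a range from 55% to 100%.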

Compound 4, a percentage reported as activity, at one concentration (the size of the read-out at that concentration, not a potency): 92%
For compound 4 the middle estimate is 10 percentage points below the measured one; the measured number falls inside the stated range.
By their numbers in this assay, from the lowest: compound 1; then compounds 4, 2 and 3 (each within the scatter of the next).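

In this assay, ethoxycarbonyl in place of trifluoromethyl on this aromatic carbon leaves the number unchanged within the scatter (a number 2 percentage points lower from compound 3 to compound 4 (within the scatter)), although the entering group brings a carbonyl and 2 hydrogen-bond acceptors where the leaving group counts 0. The same holds for the exchange with the alkyl chain (a number 1 percentage points lower from compound 2 to compound 4 (within the scatter)), so the position now accepts pentyl, trifluoromethyl and ethoxycarbonyl with no difference beyond the scatter, while the step from butyl is large (a number 32 percentage points higher from compound 1 to compound 4 (beyond the scatter)). Among the four compounds, the low number thus belongs to compound 1 alone, and nothing available explains either that exception or the level shared by the other three.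

Going by these compounds, whether the exception is tied to butyl alone remains open, and a propyl or hexyl chain on the same aromatic carbon would show whether it extends along the chain series. On these data alone, it also remains open whether the level shared by compound 2, compound 3 and compound 4 extends to a carboxylic acid, an amine or a nitrile at this position, or whether any of these would bring the number down towards that of compound 1.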